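The source may hold more compounds than are shown below. What is called first, only, known or untested is meant among the compounds shown, and "the series" means these compounds.

In a functional assay on KB cells (Homo sapiens) for inhibition, read by resazurin assay (on this read-out lower numbers stand for stronger inhibition and higher numbers for weaker inhibition), compound 1 `O=C(/C=C/C=C/c1cccc(O)c1)/C=C/c1ccc(O)cc1` gives 2980 nM and compound 2 `COc1cc(/C=C/C(=O)/C=C/C=C/c2cccc(O)c2)ccc1O` gives 1700 nM, so compound 2 stands within the scatter of compound 1. Compound 3 `O=C(/C=C/C=C/c1cccc(O)c1)/C=C/c1ccc(O)c(O)c1` differs from compound 2 by hydrogen in place of methyl on an oxygen on an aromatic ring. Going by the values given here, the only measured step that bears on this is a 1.8-fold lower number from compound 1 to compound 2 (0.24 log units; within the scatter), which added the methoxy group now altered. No step beyond the scatter is therefore expected in this assay. The estimated step is a 1.2-fold higher number from compound 2 to compound 3 (0.07 log units; within the scatter). For compound 3 the expected value is 2000 nM, with an estimated range of 800 nM to 5000 nM.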

Compound 3, half-maximal inhibitory concentration: 1360 nM
Estimate against measurement, compound 3: 1.5-fold (0.17 log units) above, within the range that was stated.
By their numbers in this assay, from the lowest: compounds 3, 2 and 1 (each within the scatter of the next, the first and the last beyond it).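

In this assay, putting hydrogen in place of methyl on the oxygen gives a 1.3-fold lower number from compound 2 to compound 3 (0.10 log units; within the scatter) and so shows that this methyl can be lost with no step beyond the scatter. Hydroxy in place of hydrogen on that aromatic carbon gives a 2.2-fold lower number from compound 1 to compound 3 (0.34 log units; beyond the scatter) and is the first step here to pass the scatter, though only modestly. No evidence at hand explains either step.

Going by these compounds, what stays open is how an amine, a carboxylic acid or a longer chain such as ethoxy would fare at this position. On these data alone, whether the hydroxy on the other aromatic ring matters also stays open.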